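Replacing the aryl on the piperazine: compound 2 to compound 4

The source may report more compounds than this note shows. Statements on the series, on what has been measured and on what is new or still open speak of the compounds shown alone.

Compound 2 `Cc1ccc(N2CCN(CC(=O)Nc3nc4c(s3)CCCC4)CC2)cc1` gives 4.8 in a physicochemical assay for lipophilicity, in phosphate buffer, measured as octanol-water partition, at pH 7.4; a higher number here means a more lipophilic compound, a lower number a more polar compound. Its nearest neighbour on the numbers is compound 1 `O=C(CN1CCN(c2ccc(F)cc2)CC1)Nc1nc2c(s1)CCCC2`, which gives 4.5 in this assay, and the furthest is compound 3 `O=C(CN1CCN(c2ccc(F)cc2)CC1)Nc1nc2ccccc2s1`, which gives 4.4. The step of a number 0.30 log units higher from compound 1 to compound 2 (within the scatter) is the only one in the set that touches the aryl on the piperazine, and it lies within the scatter, so it says little about the aryl's weight in the numbers. Compound 2 and compound 3 are not a single-point pair, and their values are simply noted as they stand.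

Compound 4 `O=C(CN1CCN(c2ccccn2)CC1)Nc1nc2c(s1)CCCC2` is the next compound for this assay. Against compound 2 the change is pyridin-2-yl in place of 4-methylphenyl on an amine nitrogen in a ring. Within the data shown here, no measured step covers an exchange of a carbon ring for a ring with one hetero atom at this position, so the expectation for compound 4 rests on the direction such a change usually takes in this assay rather than on a measured pair here. For compound 4 the expected step is a number 1.30 log units lower from compound 2 to compound 4 (beyond the scatter), downward and beyond the scatter. The estimate for compound 4 in this assay is 3.5, with a range from 3 to 4.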

Compound 4, distribution coefficient: 3.9
Beside the measured number, compound 4's estimate is 0.40 log units below it, within the range that was stated.
By their numbers in this assay, from the lowest: compound 4; then compounds 3, 1 and 2 (each within the scatter of the next, the first and the last beyond it).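

In this assay, the aryl on the amine nitrogen in a ring now shows steps beyond the scatter: pyridin-2-yl in place of 4-methylphenyl gives a number 0.90 log units lower from compound 2 to compound 4 (beyond the scatter), and pyridin-2-yl in place of 4-fluorophenyl gives a number 0.60 log units lower from compound 1 to compound 4 (beyond the scatter). Both steps run downward, so with the shared core held constant, the exchange of a six-membered aromatic ring of carbon only for one with 1 hetero atom moves the number at this position, whereas the exchange between the two carbon rings, a number 0.30 log units higher from compound 1 to compound 2 (within the scatter), stays within the scatter. The data hold no measurement that accounts for the size of these steps.

On these data alone, whether a pyrimidin-2-yl group or a saturated ring such as cyclohexyl at this position would extend the downward shift or reverse it stays open. Also open is whether pyridin-2-yl gives a step of similar size on the core of compound 3, since that core carries only 4-fluorophenyl among the compounds shown.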